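Bromine for Chlorine on Two Related Cores

The source may hold more compounds than are shown below. What is called first, only, known or untested is meant among the compounds shown, and "the series" means these compounds.

The measured compounds so far:
compound 1, `CN1C(=O)C2(C(C#N)=C(N)Oc3cc4oc(-c5ccccc5)cc(=O)c4c(O)c32)c2cc(Cl)ccc21`, 21400 nM;
compound 2, `CN1C(=O)C2(C(C#N)=C(N)Oc3cc4oc(-c5ccccc5)cc(=O)c4c(O)c32)c2cc(Br)ccc21`, 20300 nM;
compound 3, `N#CC1=C(N)Oc2cc3oc(-c4ccccc4)cc(=O)c3c(O)c2C12C(=O)Nc1cc(Cl)ccc12`, 25700 nM.

All three were tested in a functional assay on PC-3 cells (Homo sapiens) for antiproliferative activity, read by MTT assay, with a stated time of 48 h; on this read-out higher numbers stand for weaker inhibition and lower numbers for stronger inhibition. Compound 1 and compound 2 share one core and differ in a single place, (bromo in place of chloro on an aromatic carbon); the measured step was a 1.1-fold lower number from compound 1 to compound 2 (0.02 log units; within the scatter). Compound 3 is built on a second core; the difference between the two cores is not broken down here. The numbers for compound 1 and compound 3 lie within the scatter of each other, as do those for compound 2 and compound 3.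

Compound 4, `N#CC1=C(N)Oc2cc3oc(-c4ccccc4)cc(=O)c3c(O)c2C12C(=O)Nc1cc(Br)ccc12`, has not yet been measured. It differs from compound 3 by bromo in place of chloro on an aromatic carbon. The surroundings of the exchange read the same, word for word, as for the earlier pair, so this is the same change on the second core. Compound 4 is expected to show a step of about the same size, a 1.1-fold lower number from compound 3 to compound 4 (0.03 log units; within the scatter), because the earlier pair gave a 1.1-fold lower number from compound 1 to compound 2 (0.02 log units; within the scatter). Compound 4 is therefore estimated at 24000 nM, with an expected range from 12000 nM to 48000 nM.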

Compound 4, half-maximal inhibitory concentration: 24800 nM
Compound 4: the middle estimate sits 1.0-fold (0.01 log units) below what was measured; low and high end bracket the measured number.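

In this assay, bromo in place of chloro on the core of compound 3 gave a 1.0-fold lower number from compound 3 to compound 4 (0.02 log units; within the scatter). Set beside the same exchange on the core of compound 1, the step carried over from one core to the other without a difference beyond the scatter: the same change on two cores in this assay, a 1.1-fold lower number (0.02 log units; within the scatter) from compound 1 to compound 2 and a 1.0-fold lower number (0.02 log units; within the scatter) from compound 3 to compound 4, 1.0-fold (0.01 log units) apart, within the scatter of two such steps. Among the compounds shown here, this agreement is of a limited kind, since both steps lie within the scatter: the two pairs show only that this one exchange made no measurable difference on either core in this one assay, and they say little about whether a change with a real effect on one core would carry over to the other.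

The compounds shown leave open whether a different group at that place, such as an amine, a methoxy group or a carboxylic acid, would give a step beyond the scatter on either core. They also leave open whether two such steps would then match as closely as these do.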